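A few compounds are considered here, and "the series" means these few. Any claim that something is new, unique, unknown or untested is made for them only; others in the source may bear on it.

The measured compounds and their values in a functional assay on the whole organism for inhibition, with Rattus norvegicus as the target, at a dose of 3 mg/kg (a lower number here means less inhibition, a higher number more inhibition at the dose given (going by the name of the read-out)), are these:

Compound 1 `C/C(=N\OCCC(C)(c1ccc(OCc2ccc3ccccc3n2)cc1)c1ccc(OCc2ccc3ccccc3n2)cc1)C(=O)O` gives 23% in this assay.
Compound 2 `O=C(O)C#CC(O)(c1ccc(OCc2ccc3ccccc3n2)cc1)c1ccc(OCc2ccc3ccccc3n2)cc1` gives 48% in this assay.
Compound 3 `OC(c1ccc(OCc2ccc3ccccc3n2)cc1)(c1ccc(OCc2ccc3ccccc3n2)cc1)c1cccs1` gives 0% in this assay.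

Compound 1 stands second highest of the three numbers. Its nearest neighbour is compound 3, which lies lower by a step beyond the scatter, and compound 2 lies above it, again beyond the scatter. Going by the values given here, the one single-place step that has been measured is a number 48 percentage points lower from compound 2 to compound 3 (beyond the scatter), where a thiophen-2-yl group replaces 2-carboxyethynyl and the carboxylic acid is lost altogether.

Compound 4 `CC(SCC(=O)O)(c1ccc(OCc2ccc3ccccc3n2)cc1)c1ccc(OCc2ccc3ccccc3n2)cc1` has not yet been measured. Its change from compound 1 is a group of 5 heavy atoms (2 carbon, 2 oxygen, 1 sulfur; no ring) in place of a group of 9 heavy atoms (5 carbon, 1 nitrogen, 3 oxygen; no ring), on a saturated chain carbon bound to two aromatic carbons and a saturated chain carbon. Among the compounds with values here, no measured step covers this change directly: the step from compound 2 to compound 3 removes the acid, whereas compound 4 keeps a carboxylic acid on a shorter, sulfur-containing chain. Both measured compounds that carry an acid, compound 1 and compound 2, give a number clearly above compound 3, which has none. On that basis compound 4 is expected to stay in the range of the acid-bearing compounds, with a step of a number 2 percentage points higher from compound 1 to compound 4 (within the scatter) that is expected to lie within the scatter. The estimate for compound 4 is 25%, expected to fall between 5% and 50%.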

Compound 4, a percentage reported as inhibition, in the whole organism at one dose (the size of the read-out at that dose, not a potency): 0%
Beside the measured number, compound 4's estimate is 25 percentage points above it; the whole stated range lies above it.
By their numbers in this assay, from the lowest: compounds 3 and 4 (each within the scatter of the next); then compound 1; then compound 2.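

The step of a number 23 percentage points lower from compound 1 to compound 4 (beyond the scatter) in this assay shows that, on a saturated chain carbon bound to two aromatic carbons and a saturated chain carbon, a carboxylic acid in the group does not by itself preserve the read-out. Going by these compounds alone, the one earlier single-place step, from a group with the acid to thiophen-2-yl, took the acid away, whereas here both the leaving group and (carboxymethyl)sulfanyl carry one, and compound 4 still gives 0%. The rest of the group at this position therefore matters as well, though nothing at hand accounts for the fall.

The compounds shown leave open which part of the change counts, since the sulfur, the smaller group and the loss of one double bond outside aromatic rings all arrive together in this single step. Also open, from the compounds shown here alone, is whether a longer chain ending in a carboxylic acid on the same sulfur, or an oxygen in place of that sulfur in (carboxymethyl)sulfanyl, would give a number nearer that of compound 1 at this dose.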